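The compounds below may be only part of what the source reports. "The series", "measured", "known", "first", "only" and "open" are said of these compounds alone.

Compound 1 `CCSc1nc(N)c2nc(O)n(Cc3ccccc3)c2n1` has been tested in a functional assay (spleen, spleen) for activation, with Mus musculus as the target (on this read-out lower numbers stand for an effect already at smaller amounts and higher numbers for an effect only at larger amounts of compound), where compound 1 gives 0.1 uM. Among the numbers known in this assay, that is the lowest of the two. The nearest is compound 3 `COc1ccccc1Cn1c(O)nc2c(N)ncnc21`, which in this assay gives 10 uM, a gap beyond the usual scatter. Compound 2 `Nc1ncnc2c1nc(I)n2Cc1ccccc1` in this assay returns only a limit, > 10 uM, and not a number (the limit of > 10 uM in this assay, at which 1 of the 3 values shown sits). Compound 4 `CCCC[S+]([O-])c1nc(N)c2nc(O)n(Cc3ccccc3)c2n1` has not yet been measured. It differs from compound 1 in a single place: a group of 6 heavy atoms (4 carbon, 1 oxygen, 1 sulfur; no ring) in place of a group of 3 heavy atoms (2 carbon, 1 sulfur; no ring), on an aromatic carbon. Within the data shown here, no measured pair shows a change of this kind, and a modest loss is expected. In this assay the expected step is a 3.0-fold higher number from compound 1 to compound 4 (0.48 log units; beyond the scatter). Compound 4 is estimated at 0.3 uM, within a range from 0.05 uM to 3 uM.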

Compound 4, minimum effective concentration: 0.01 uM
For compound 4 the middle estimate is 30-fold (1.48 log units) above the measured one; measured number below the stated range.
By their numbers in this assay, from the lowest: compound 4; then compound 1; then compound 3.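

In this assay, the aromatic carbon between two ring nitrogen atoms accepts a bigger sulfur-bearing group, with a 10-fold lower number from compound 1 to compound 4 (1.00 log units; beyond the scatter) as the step seen here. Among these compounds, no earlier pair touched this place, so this is the first sign that the number can fall when the group there grows from 3 to 6 heavy atoms. Nothing measured here explains the step. From the compounds shown here alone, it remains open whether the longer chain or the added oxygen carries the step, which butylsulfanyl would help separate. Going by these compounds, how an amine or a still longer chain would behave on this carbon also remains open.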